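The source may hold more compounds than are shown below. What is called first, only, known or untested is meant among the compounds shown, and "the series" means these compounds.

Compound 2 `Fc1ccc(C2(c3ccc(F)cc3)CNC(c3ccsc3)=N2)cc1` and compound 1 `Fc1ccc(C2(c3ccc(F)cc3)CNC(c3ccccc3)=N2)cc1` share a core that carries two 4-fluorophenyl groups and differ only in the aryl group on a carbon with a double bond to nitrogen. In an assay on LM cells for displacement of a labelled ligand from Neuropeptide Y receptor type 5 (Homo sapiens) (on this read-out lower numbers stand for stronger inhibition and higher numbers for weaker inhibition), compound 1 gives 32 nM, while compound 2 gives 93 nM. Going by the values given here, the single measured step, a 2.9-fold higher number from compound 1 to compound 2 (0.46 log units; beyond the scatter), is therefore a modest weakening, and compound 2 stands as the higher of the two numbers measured so far.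

Compound 3 `N#Cc1cccc(C2=NC(c3ccc(F)cc3)(c3ccc(F)cc3)CN2)n1` is the next step in this direction: 6-cyanopyridin-2-yl in place of thiophen-3-yl on a carbon with a double bond to nitrogen. Among the compounds with values here, only the step from compound 1 to compound 2 bears on this change, and it shows that swapping the aryl group at this carbon moves the number, as a 2.9-fold higher number from compound 1 to compound 2 (0.46 log units; beyond the scatter) records. The 6-cyanopyridin-2-yl group is a six-membered aromatic ring, closer in size to the phenyl of compound 1 than to the thiophen-3-yl it replaces, so the expected outcome in this assay for compound 3 is a shift of about a 1.6-fold lower number from compound 2 to compound 3 (0.19 log units; within the scatter) back toward the number of compound 1. The estimated value for compound 3 is thus 60 nM, with a range from 15 nM to 250 nM.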

Compound 3, half-maximal inhibitory concentration: 39 nM
For compound 3 the middle estimate is 1.5-fold (0.19 log units) above the measured one, and the stated range covers the measured number.
By their numbers in this assay, from the lowest: compounds 1 and 3 (each within the scatter of the next); then compound 2.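

In this assay, the 6-cyanopyridin-2-yl group shows that the number at this carbon can come down again after the rise seen with thiophen-3-yl, with a 2.4-fold lower number from compound 2 to compound 3 (0.38 log units; beyond the scatter), a step beyond the scatter. Set against phenyl, the same group gives a 1.2-fold higher number from compound 1 to compound 3 (0.09 log units; within the scatter), which lies within the scatter, so this position accepts a ring nitrogen and a nitrile together without a change that can be read, and compound 1 and compound 3 cannot be ranked. Nothing measured here accounts for either step, so the reason for these numbers remains unknown.

The compounds shown do not separate the part played by the ring nitrogen from that of the nitrile, which plain pyridin-2-yl and 3-cyanophenyl would address. As far as these compounds go, all three groups at this carbon are aromatic rings, so the outcome with a saturated ring such as cyclohexyl, an open chain such as n-butyl, or a group bearing an amine or a carboxylic acid remains open.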